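Varying the Ether Group on the Shared Core

The source may report more compounds than this note shows. Statements on the series, on what has been measured and on what is new or still open speak of the compounds shown alone.

Measured compounds:
compound 1 `CCc1sc(CCc2cc(OC(C)C)cc(NCc3cc(Cl)cc(NC(=O)OC(C)C)c3)n2)nc1C` — 12 nM
compound 2 `CCc1sc(CCc2cc(OC3CCC3)cc(NCc3cc(Cl)cc(NC(=O)OC(C)C)c3)n2)nc1C` — 11 nM
compound 3 `CCc1sc(CCc2cc(OC3CCOCC3)cc(NCc3cc(Cl)cc(NC(=O)OC(C)C)c3)n2)nc1C` — 4.4 nM

Three compounds share one core and differ only in the group carried on an oxygen on an aromatic ring. In an assay on cells for binding affinity to Neuropeptide Y receptor type 1 (Homo sapiens) (on this read-out higher numbers stand for weaker inhibition and lower numbers for stronger inhibition), compound 1 gives 12 nM, the highest of the three numbers; compound 2 gives 11 nM and compound 3 gives 4.4 nM. The step of a 1.1-fold lower number from compound 1 to compound 2 (0.04 log units; within the scatter) stays within the scatter, whereas a 2.7-fold lower number from compound 1 to compound 3 (0.44 log units; beyond the scatter) and a 2.5-fold lower number from compound 2 to compound 3 (0.40 log units; beyond the scatter) are modest but beyond it.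

Compound 4 `CCc1sc(CCc2cc(OCCCc3cccnc3)cc(NCc3cc(Cl)cc(NC(=O)OC(C)C)c3)n2)nc1C` has not yet been measured in this assay. It differs from compound 1 by 3-(pyridin-3-yl)propyl in place of isopropyl on an oxygen on an aromatic ring. The measured steps show that this oxygen tolerates a change of group, with a small ring giving no shift and a ring holding one hetero atom giving a modest gain; none of them tested an open chain ending in an aromatic ring, so they bear on compound 4 only loosely. The step is therefore expected to be small, a 1.3-fold lower number from compound 1 to compound 4 (0.12 log units; within the scatter), with a lean toward a lower number resting on the gain seen in a 2.7-fold lower number from compound 1 to compound 3 (0.44 log units; beyond the scatter) for compound 3 but with wide uncertainty. Compound 4 is accordingly expected to give about 9 nM in this assay, between 3 nM and 30 nM.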

Compound 4, half-maximal inhibitory concentration: 6.5 nM
For compound 4 the middle estimate is 1.4-fold (0.14 log units) above the measured one; the measured number falls inside the stated range.
By their numbers in this assay, from the lowest: compounds 3, 4, 2 and 1 (each within the scatter of the next, the first and the last beyond it).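

In this assay the open chain 3-(pyridin-3-yl)propyl, which brings 9 heavy atoms in place of the 3 of isopropyl, is taken up on this oxygen with a 1.8-fold lower number from compound 1 to compound 4 (0.27 log units; within the scatter) and no loss outside the scatter. Against the two ring groups the picture is the same, with a 1.7-fold lower number from compound 2 to compound 4 (0.23 log units; within the scatter) and a 1.5-fold higher number from compound 3 to compound 4 (0.17 log units; within the scatter) both inside the scatter, so compound 4 cannot be told apart from any of the other three, and this position is shown to accept a much larger group ending in an aromatic ring, not only small rings. Nothing available explains why the numbers stay so close.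

The compounds shown leave open whether the pyridine nitrogen counts for anything here, which a phenyl ring at the end of the same propyl chain would address, and whether the length of the chain matters, which a 2-(pyridin-3-yl)ethyl or a longer 4-(pyridin-3-yl)butyl group would address. They also leave open how an amine on this oxygen, such as a piperidin-4-yl group, or a carboxylic acid at the end of a chain would fare.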